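A few compounds are considered here, and "the series" means these few. Any claim that something is new, unique, unknown or untested is made for them only; others in the source may bear on it.

In a functional assay on HCC827 cells (Homo sapiens) for cytotoxicity, read by MTT assay, with a stated time of 72 h; on this read-out lower numbers stand for stronger inhibition and higher numbers for weaker inhibition:
- compound 1 `CN1CCN(c2ccc(Nc3ncc4nc(Nc5ccccc5)n(C5CCCCC5)c4n3)cc2)CC1`: < 0.01 nM
- compound 2 `C#Cc1cccc(Nc2nc3cnc(Nc4ccc(N5CCN(C)CC5)cc4)nc3n2C2CCCC2)c1`: < 0.01 nM

Both entries are limits of the assay and not numbers. Going by the values given here, compound 2 stands at the limit of < 0.01 nM in this assay, at which 2 of the 2 values shown sit, so no measured step is available to size a change from it. Compound 3 `CN1CCN(c2ccc(Nc3ncc4nc(Nc5ccc(Br)cc5F)n(C5CCCC5)c4n3)cc2)CC1` carries 4-bromo-2-fluorophenyl in place of 3-ethynylphenyl on a nitrogen on an aromatic ring. A modest move toward weaker inhibition is expected, with an estimated at least 3.0-fold higher number from compound 2 to compound 3 (0.47 log units; beyond the scatter), though the result may again be only a limit. For compound 3 the expected value in this assay is 0.03 nM, with an estimated range of 0.005 nM to 1 nM.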

Compound 3, half-maximal inhibitory concentration: 2.3 nM
Estimate against measurement, compound 3: 77-fold (1.88 log units) below, and the stated range ends below it.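

In this assay, going by these compounds alone, the group on this nitrogen proves to matter: 4-bromo-2-fluorophenyl in place of 3-ethynylphenyl gives an at least 230-fold higher number from compound 2 to compound 3 (2.36 log units; beyond the scatter), and compound 3 holds the only value shown that is a number and not a limit. The size of this step is a lower bound only, as it starts from a limit: the limit of < 0.01 nM in this assay, at which 2 of the 3 values shown sit.

The compounds shown leave open whether the bromine, the fluorine or the loss of the ethynyl group carries the step. They also leave open how a nitrile or a methoxy group on this phenyl ring would read.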